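A longer nitrile chain on compound 2

The source may report more compounds than this note shows. Statements on the series, on what has been measured and on what is new or still open speak of the compounds shown alone.

In a functional assay on LoVo cells (Homo sapiens) for cytotoxicity, read by colorimetric assay and MTT assay (on this read-out higher numbers stand for weaker inhibition and lower numbers for stronger inhibition), compound 1 `CCOC(=O)Cn1c(=O)c(-c2ccc(OC)cc2)cc2c(OC)cc(OC)cc21` gives 10000 nM, and compound 2 `COc1ccc(-c2cc3c(OC)cc(OC)cc3n(CC#N)c2=O)cc1` gives 10000 nM. Among the compounds with values here, compound 2 therefore stands level with compound 1, its only measured neighbour. These two differ in a single place, where cyano takes the place of ethoxycarbonyl on a saturated chain carbon bound to an aromatic nitrogen, and the result is no change at the digits printed from compound 1 to compound 2 (within the scatter).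

Compound 3 `COc1ccc(-c2cc3c(OC)cc(OC)cc3n(CCCC#N)c2=O)cc1` keeps the shared core and the nitrile but changes that same place: 2-cyanoethyl in place of cyano on a saturated chain carbon bound to an aromatic nitrogen. In words, 2-cyanoethyl stands in place of cyano, which means the cyanomethyl group becomes 3-cyanopropyl.

Within the data shown here, no measured pair yet shows what a longer chain does, so the evidence is thin. Among the measured compounds shown here, the only guide is no change at the digits printed from compound 1 to compound 2 (within the scatter), a swap of one end group that left the value level. No shift beyond the scatter is therefore expected, and the estimated step is no change at the digits printed from compound 2 to compound 3 (within the scatter). In this assay, the estimated value for compound 3 is 10000 nM, with an expected range from 4000 nM to 20000 nM.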

Compound 3, half-maximal inhibitory concentration: 10000 nM
Estimate against measurement, compound 3: no gap at the digits printed; measured number inside the range.
By their numbers in this assay, from the lowest: compounds 1, 2 and 3 (each within the scatter of the next).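

In this assay, swapping the nitrile-bearing chain gives no change at the digits printed from compound 2 to compound 3 (within the scatter), so going from cyanomethyl to 3-cyanopropyl, with the nitrile still at the end of the chain, does not separate the two compounds on this read-out. Setting 2-cyanoethyl directly against ethoxycarbonyl gives no change at the digits printed from compound 1 to compound 3 (within the scatter), so three different groups on this saturated chain carbon bound to an aromatic nitrogen now stand at the same printed value, and chain length joins the change of end group as a difference that leaves the number level. Nothing available here explains why the value stays the same across these changes.

From the compounds shown here alone, it remains open whether any group at this place can move the number at all: a primary amine or a carboxylic acid at the end of the chain, or a chain longer than 3-cyanopropyl, would put that to the test. Going by these compounds, with all three values level, it also stays open whether this place matters for the read-out, or whether changes elsewhere on the shared core would be needed to shift it.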